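The compounds below may be only part of what the source reports. "The series", "measured", "known", "first", "only" and "open" are said of these compounds alone.

Measured in a functional assay on A549 cells (Homo sapiens) for inhibition, read by MTT assay, with a stated time of 48 h; on this read-out higher numbers stand for weaker inhibition and lower numbers for stronger inhibition:
Compound 1 `COc1ccc(CNC(=O)/C=C/c2coc3cc(O)ccc3c2=O)cc1`: > 100000 nM, a limit
Compound 2 `Cc1ccccc1NC(=O)/C=C/c1coc2cc(O)ccc2c1=O`: > 100000 nM, a limit
Compound 3 `Cc1ccc(CNC(=O)/C=C/c2coc3cc(O)ccc3c2=O)cc1`: 17400 nM

Going by the values given here, compound 3 is the strongest of the three and the only one to give a number. The other two lie at the limit of > 100000 nM in this assay, at which 2 of the 3 values shown sit.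

Compound 4 `O=C(/C=C/c1coc2cc(O)ccc2c1=O)NCc1ccc(F)cc1F` keeps the shared core and the amide chain of compound 3, with 2,4-difluorophenyl in place of 4-methylphenyl on a saturated chain carbon bound to an amide-type nitrogen.

Among the compounds with values here, two measured steps bear on this end of the molecule. One is an at least 5.7-fold lower number from compound 1 to compound 3 (0.75 log units; beyond the scatter), with methyl in place of methoxy on an aromatic carbon. The other is an at least 5.7-fold lower number from compound 2 to compound 3 (0.75 log units; beyond the scatter), with 4-methylbenzyl in place of 2-methylphenyl on an amide-type nitrogen. Both changes away from compound 3 at 17400 nM gave weaker compounds, so a modest rise in the number is expected in this assay. A result at the limit would be no surprise for compound 4. The expected step is a 2.3-fold higher number from compound 3 to compound 4 (0.36 log units; beyond the scatter). Compound 4 is estimated at 40000 nM, with an expected range from 12000 nM to 100000 nM.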

Compound 4, half-maximal inhibitory concentration: 6610 nM
The estimate for compound 4 lay 6.1-fold (0.78 log units) above the measured number; the measured number lies below the stated range.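

In this assay, the earlier changes at this end of the molecule had only given weaker compounds, but 2,4-difluorophenyl in place of 4-methylphenyl on a saturated chain carbon bound to an amide-type nitrogen gives a 2.6-fold lower number from compound 3 to compound 4 (0.42 log units; beyond the scatter). The position can therefore gain as well as lose, and the replacement of 4-methoxyphenyl by the same 2,4-difluorophenyl gives a wider gap, an at least 15-fold lower number from compound 1 to compound 4 (1.17 log units; beyond the scatter). That wider step can be read only as a bound, as compound 1 gives a limit and no number: the limit of > 100000 nM in this assay, at which 2 of the 4 values shown sit.

The compounds shown leave open whether one fluorine alone, as in 4-fluorophenyl, would give the same gain, as compound 4 carries both fluorines together. They also leave open how 4-chlorophenyl, a pyridine ring or a longer chain between the amide nitrogen and the ring would read in this assay.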